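Dimethylphenyl Analogue Weighed Against Three Measured Precedents

This account rests on a few compounds, and the source may have more. Where it says the series, first, only, none or still open, it means among the compounds named here.

Compound 3 `CCC1=C(O)c2c(oc(-c3ccc(CBr)cc3)cc2=O)C(CC)(CC)C1=O` reaches only a limit in a functional assay on KB cells (Homo sapiens) for antiproliferative activity, read by sulforhodamine B assay, with a stated time of 3 days (on this read-out lower numbers stand for an effect already at smaller amounts and higher numbers for an effect only at larger amounts of compound), recorded as > 46.5 uM. That limit is the one marked by the limit of > 46.5 uM in this assay, at which 1 of the 3 values shown sits. Compound 1 `CCC1=C(O)c2c(oc(-c3ccc(O)cc3)cc2=O)C(CC)(CC)C1=O` gives a number in this assay, 20.6 uM. Compound 2 `CCC1=C(O)c2c(oc(-c3ccc(SC)cc3)cc2=O)C(CC)(CC)C1=O` likewise stops at a limit in this assay, > 52.1 uM, the one shown by the limit of > 52.1 uM in this assay, at which 1 of the 3 values shown sits. The two measured steps leaving compound 1 run an at least 2.5-fold higher number from compound 1 to compound 2 (0.40 log units; beyond the scatter) and an at least 2.2-fold higher number from compound 1 to compound 3 (0.35 log units; beyond the scatter), while a step that the two limits leave unreadable from compound 2 to compound 3. Compound 4 `CCC1=C(O)c2c(oc(-c3ccc(C)c(C)c3)cc2=O)C(CC)(CC)C1=O` is not yet measured; it differs from compound 3 as 3,4-dimethylphenyl in place of 4-(bromomethyl)phenyl on an aromatic carbon. Within the data shown here, no measured step removes a bromomethyl or adds methyl groups, so the change has no direct precedent; what the measured compounds show is that only the hydroxy-bearing compound 1 yields a number, while the other two substituents end at limits. The step of an at least 1.0-fold lower number from compound 3 to compound 4 (0.01 log units; that floor lies within the scatter) is therefore expected to be small, with compound 4 probably again ending near or beyond a limit. Compound 4 is estimated at 45 uM in this assay, with a range from 15 uM to 120 uM.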

Compound 4, concentration for half-maximal effect: 35.5 uM
Estimate against measurement, compound 4: 1.3-fold (0.10 log units) above; the measured number falls inside the stated range.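

In this assay compound 4 ends at a number rather than a limit, so on this aromatic carbon a readable value no longer belongs to the hydroxy-bearing compound 1 alone. The comparison with that compound gives a 1.7-fold higher number from compound 1 to compound 4 (0.24 log units; within the scatter) and the entering 3,4-dimethylphenyl has no hydrogen-bond donors, so a hydroxy group is not required for a number here. Against the two compounds that stop at limits, the steps are only floors, namely an at least 1.3-fold lower number from compound 3 to compound 4 (0.11 log units; that floor lies within the scatter) and an at least 1.4-fold lower number from compound 2 to compound 4 (0.16 log units; that floor lies within the scatter) and neither fixes how far compound 4 truly lies from them.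

The compounds shown leave open whether a single methyl group on the phenyl ring would serve as well as the pair. They also leave open how an amine or a carboxylic acid on that phenyl ring would read.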